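A few compounds are considered here, and "the series" means these few. Any claim that something is new, unique, unknown or untested is made for them only; others in the source may bear on it.

Measured so far:
Compound 1 `C/C(=C\c1ccccc1)C(=O)/C=C/c1ccc([N+](=O)[O-])cc1`: 43300 nM
Compound 2 `C/C(=C\c1ccccc1)C(=O)/C=C/c1ccc(N(C)C)cc1`: 53000 nM

In an ADME assay on LLC-MK2 cells (Macaca mulatta) for cytotoxicity, read by MTT assay, with a stated time of 48 h (on this read-out higher numbers stand for lower toxicity in this test and lower numbers for higher toxicity in this test), compound 1 gives 43300 nM. Among the compounds with values here, it is one of only two measured compounds, and compound 2 lies within the scatter of it at 53000 nM.

The next compound, compound 3 `C/C(=C\c1ccc(N(C)C)cc1)C(=O)/C=C/c1ccc([N+](=O)[O-])cc1`, keeps the nitro group of compound 1 and adds a new group: dimethylamino in place of hydrogen on an aromatic carbon. In words, dimethylamino stands in place of hydrogen on an aromatic carbon of a six-membered aromatic ring of carbon only, para to a large group.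

Within the data shown here, only one measured step bears on this change, and it does so indirectly. In that step dimethylamino replaces nitro rather than hydrogen, and the result is a 1.2-fold higher number from compound 1 to compound 2 (0.09 log units; within the scatter). That single pair gives no sign that dimethylamino shifts the number, but it cannot show what happens when the group replaces hydrogen. No step beyond the scatter is therefore expected, though the range is kept wide.

For compound 3 the estimated value is 42000 nM. The expected range for compound 3 runs from 16000 nM to 95000 nM. The estimate means an expected 1.0-fold lower number from compound 1 to compound 3 (0.01 log units; within the scatter).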

Compound 3, half-maximal cytotoxic concentration: 167000 nM
Compound 3: the middle estimate sits 4.0-fold (0.60 log units) below what was measured; measured number above the stated range.
By their numbers in this assay, from the lowest: compounds 1 and 2 (each within the scatter of the next); then compound 3.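

In this assay, within the data shown here, dimethylamino in place of hydrogen on an aromatic carbon, para to a large group, gives a 3.9-fold higher number from compound 1 to compound 3 (0.59 log units; beyond the scatter), the first step in this set beyond the scatter and one toward lower toxicity in this test. The earlier step, a 1.2-fold higher number from compound 1 to compound 2 (0.09 log units; within the scatter), placed the same group where compound 1 carries its nitro group and stayed within the scatter, so the two steps from compound 1 show that the place dimethylamino takes matters here, at least for these compounds. No measurement shown here accounts for the rise seen with compound 3.

As far as these compounds go, it remains open whether the rise is particular to dimethylamino or would also appear with a plain amino group, a methoxy group or a chlorine atom at the same place on the core of compound 1. From the compounds shown here alone, it is also open whether dimethylamino at this place would give a step of similar size if the nitro group kept in compound 3 were replaced by another group, such as a nitrile or a carboxylic acid.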